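The compounds below may be only part of what the source reports. "The series", "measured", "known", "first", "only" and "open" are said of these compounds alone.

Compound 1 `CN1CCN(c2ccc(Nc3ncc(/N=C/c4cccs4)c(NC4CCCC4)n3)cc2)CC1` gives 18900 nM in a functional assay on HCT-116 cells (Homo sapiens) for antiproliferative activity, read by MTT assay; a lower number here means a stronger inhibitor, a higher number a weaker inhibitor. Compound 2 `CN1CCN(c2ccc(Nc3ncc(/N=C/c4ccc(C(F)(F)F)cc4)c(NC4CCCC4)n3)cc2)CC1` reaches only > 100000 nM in this assay, which is a limit of the measurement and not a number. Going by the values given here, the one measured step, an at least 5.2-fold higher number from compound 1 to compound 2 (0.72 log units; beyond the scatter), leaves compound 2 sitting at the limit of > 100000 nM in this assay, at which 1 of the 2 values shown sits. Compound 3 `CC(C)Nc1nc(Nc2ccc(N3CCN(C)CC3)cc2)ncc1/N=C/c1ccc(C(F)(F)F)cc1` differs from compound 2 by isopropyl in place of cyclopentyl on a nitrogen on an aromatic ring. Among the compounds with values here, no measured step touches this change, so no shift beyond the usual scatter is expected, and a limit is again likely. Compound 3 is therefore estimated at 150000 nM, with a range from 50000 nM to 500000 nM, an expected step that the limit leaves unreadable from compound 2 to compound 3 that is essentially flat.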

Compound 3, half-maximal inhibitory concentration: 42200 nM
Compound 3: the middle estimate sits 3.6-fold (0.55 log units) above what was measured; the whole stated range lies above it.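

The group on this nitrogen does affect the result in this assay: isopropyl in place of cyclopentyl gives an at least 2.3-fold lower number from compound 2 to compound 3 (0.37 log units; beyond the scatter). So this position can move the number even with the 4-(trifluoromethyl)phenyl group in place. The true size of the step stays unknown because compound 2 marks only a limit of the measurement: the limit of > 100000 nM in this assay, at which 1 of the 3 values shown sits.

As far as these compounds go, whether the change matters through losing the ring or losing carbons stays open, and cyclopropyl or a longer chain such as n-butyl could separate the two. From the compounds shown here alone, whether the same change would hold with thiophen-2-yl also stays open.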